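The source may report more compounds than this note shows. Statements on the series, on what has been measured and on what is new or still open speak of the compounds shown alone.

Series notes. Compound 1 `COc1ccc(/C=C/c2nc(NCCN(C(C)C)C(C)C)c3cc(Cl)ccc3n2)cc1OC` carries a diisopropylamino group on the side chain; compound 2 `COc1ccc(/C=C/c2nc(NCCN3CCCCC3)c3cc(Cl)ccc3n2)cc1OC` carries piperidin-1-yl there instead, the change being (piperidin-1-yl in place of diisopropylamino on a saturated chain carbon, two bonds along the chain from a nitrogen on an aromatic ring). In a functional assay on A549 cells (Homo sapiens) for cytotoxicity, read by MTT assay, with stated times of 48 h and 4 h (on this read-out higher numbers stand for weaker inhibition and lower numbers for stronger inhibition), compound 1 gives > 100000 nM, a limit of the assay and not a number. In this assay compound 2 likewise gives > 100000 nM, again only a limit. The resulting step that the two limits leave unreadable from compound 1 to compound 2 therefore cannot be sized, because of the limit of > 100000 nM in this assay, at which 3 of the 3 values shown sit.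

Compound 3 `CC(C)N(CCNc1nc(/C=C/c2ccc([N+](=O)[O-])cc2)nc2ccccc12)C(C)C` differs from compound 1 in more than one place; the difference between the two cores is not broken down here. In this assay compound 3 gives > 100000 nM, a limit only.

Compound 4 `O=[N+]([O-])c1ccc(/C=C/c2nc(NCCN3CCCCC3)c3ccccc3n2)cc1` is not yet measured. It stands to compound 3 as compound 2 stands to compound 1: piperidin-1-yl in place of diisopropylamino on a saturated chain carbon, two bonds along the chain from a nitrogen on an aromatic ring, the same change at the same place. Given that compound 1 and compound 2 both sit at the limit, the step from compound 3 to compound 4 is expected to be a number no higher from compound 3 to compound 4 (the limit leaves the size open), that is, no readable change. Compound 4 is thus expected to give about 100000 nM in this assay, most likely reported again as a limit, within 50000 nM to 300000 nM.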

Compound 4, half-maximal inhibitory concentration: 28200 nM
Beside the measured number, compound 4's estimate is 3.5-fold (0.55 log units) above it; the measured number lies below the stated range.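

In this assay, piperidin-1-yl in place of diisopropylamino gives an at least 3.5-fold lower number from compound 3 to compound 4 (0.54 log units; beyond the scatter), and this size is only a floor, as compound 3 is known only as a limit. On the core of compound 1 the same change cannot be read, because both of its compounds sit at the limit: the limit of > 100000 nM in this assay, at which 3 of the 4 values shown sit.

Compound 4 is thus the only one of the four with a number, so the change lowers the number on one core, but nothing shows that this effect carries from one core to the other, and the two cores cannot be compared directly as they differ in more than one place.

From the compounds shown here alone, whether morpholin-4-yl, dimethylamino or a longer chain in place of 2-(piperidin-1-yl)ethyl would also give a readable number on the core of compound 4 stays open. Also open, going by these compounds, is whether any amine on this side chain would bring the core of compound 1 off the limit.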